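Triazole carboxamide series: aryl for propyl on the core

A few compounds are considered here, and "the series" means these few. Any claim that something is new, unique, unknown or untested is made for them only; others in the source may bear on it.

Measured so far in a functional assay on CHO cells for antagonist activity at prostaglandin E2 receptor EP4 subtype (Homo sapiens), read by calcium flux, with a stated time of 15 min; a higher number here means a weaker inhibitor, a lower number a stronger inhibitor:
compound 1 `CCCc1nnn(Cc2ccc(C(F)(F)F)cc2)c1C(=O)N[C@@H](C)c1ccc(C(=O)O)cc1` gives 68.8 nM
compound 2 `C[C@H](NC(=O)c1c(-c2ccccc2)nnn1Cc1ccccc1)c1ccc(C(=O)O)cc1` gives 647 nM
compound 3 `C[C@H](NC(=O)c1c(-c2ccccc2)nnn1CCOc1ccc(C(F)(F)F)cc1)c1ccc(C(=O)O)cc1` gives 49.1 nM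

Compound 1 stands second highest of the three numbers. Compound 3 is nearest to it, within the scatter. Compound 2 is furthest, beyond the scatter.

Among the compounds with values here, the only single-point step measured, a 13-fold lower number from compound 2 to compound 3 (1.12 log units; beyond the scatter), changes the group on the saturated chain carbon bound to the aromatic nitrogen and leaves the aryl on the ring carbon untouched, so it does not bear directly on the change considered here.

Compound 4 `Cc1ccc(-c2nnn(Cc3ccc(C(F)(F)F)cc3)c2C(=O)N[C@@H](C)c2ccc(C(=O)O)cc2)s1` differs from compound 1 by 5-methylthiophen-2-yl in place of propyl on an aromatic carbon. Compounds 2 and 3 both carry phenyl on that ring carbon; compound 3 differs from compound 1 in two places, and their values lie within the scatter of each other, which shows that an aromatic group there is tolerated alongside a propyl. Within the data shown here, no step isolates this change, so for compound 4 in this assay a step of about a 1.4-fold lower number from compound 1 to compound 4 (0.14 log units; within the scatter) is expected, none beyond the scatter. The estimate for compound 4 is 50 nM, with a range from 15 nM to 200 nM.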

Compound 4, half-maximal inhibitory concentration: 4.6 nM
Beside the measured number, compound 4's estimate is 11-fold (1.04 log units) above it; the whole stated range lies above it.
By their numbers in this assay, from the lowest: compound 4; then compounds 3 and 1 (each within the scatter of the next); then compound 2.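

Notes on the aromatic carbon next to the ring nitrogen: in this assay, 5-methylthiophen-2-yl in place of propyl gives a 15-fold lower number from compound 1 to compound 4 (1.17 log units; beyond the scatter) and is a large step beyond the scatter. Within the data shown here, this is the first step to isolate this position, with the 4-(trifluoromethyl)benzyl group and the rest of the molecule held constant; earlier comparisons of this position also carried a second change, so they could not show how strongly the group here alone moves the number. No available measurement explains the step.

Going by these compounds, it remains open whether the step depends on the five-membered aromatic ring or on its methyl, and an unsubstituted thiophen-2-yl would separate the two. On these data alone, how a longer chain such as butyl or a 5-chlorothiophen-2-yl group would compare on this carbon is also open.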